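The source may hold more compounds than are shown below. What is called first, only, known or untested is meant among the compounds shown, and "the series" means these compounds.

For the measured compounds named here, compound 3 `O=C1O[C@H]([C@@H](O)Cn2cc(CNS(=O)(=O)c3ccc(Cl)cc3)nn2)C(OCc2ccccc2)=C1OCc1ccccc1` gives 7510 nM in a functional assay on HepG2 cells (Homo sapiens) for antiproliferative activity, read by MTT assay, with a stated time of 72 h (a higher number here means a weaker inhibitor, a lower number a stronger inhibitor), the lowest of the three numbers measured so far. Compound 2 `O=C1O[C@H]([C@@H](O)Cn2cc(CNS(=O)(=O)c3ccc(F)cc3)nn2)C(OCc2ccccc2)=C1OCc1ccccc1` gives 18300 nM in this assay, and compound 1 `O=C1O[C@H]([C@@H](O)Cn2cc(-c3cccc(O)c3)nn2)C(OCc2ccccc2)=C1OCc1ccccc1` gives 62700 nM. Compound 4 `Cc1ccc(-c2cn(C[C@H](O)[C@H]3OC(=O)C(OCc4ccccc4)=C3OCc3ccccc3)nn2)cc1` carries 4-methylphenyl in place of (((4-chlorophenyl)sulfonyl)amino)methyl on an aromatic carbon. Compound 4, like compound 1, bears an aromatic ring of carbon only on the five-membered aromatic ring with 3 nitrogen, so the step of an 8.3-fold lower number from compound 1 to compound 3 (0.92 log units; beyond the scatter) bears on it most, with a 3.4-fold lower number from compound 1 to compound 2 (0.53 log units; beyond the scatter) and a 2.4-fold lower number from compound 2 to compound 3 (0.39 log units; beyond the scatter) alongside. A 4-methylphenyl is not a 3-hydroxyphenyl, so the size of any return is uncertain, but a rise beyond the scatter is expected. Compound 4 is expected to give 35000 nM, within 10000 nM to 100000 nM, an expected step of a 4.7-fold higher number from compound 3 to compound 4 (0.67 log units; beyond the scatter).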

Compound 4, half-maximal inhibitory concentration: 8770 nM
The estimate for compound 4 lay 4.0-fold (0.60 log units) above the measured number; the whole stated range lies above it.
By their numbers in this assay, from the lowest: compounds 3 and 4 (each within the scatter of the next); then compound 2; then compound 1.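

At this position of the five-membered aromatic ring, the sulfonyl-bearing chain is not needed to reach the lowest numbers seen so far: the shorter 4-methylphenyl gives a 1.2-fold higher number from compound 3 to compound 4 (0.07 log units; within the scatter). The aryl group attached directly to the ring is also not interchangeable, since changing 3-hydroxyphenyl to 4-methylphenyl gives a 7.1-fold lower number from compound 1 to compound 4 (0.85 log units; beyond the scatter). Compound 4 also improves on the fluoro sulfonamide, with a 2.1-fold lower number from compound 2 to compound 4 (0.32 log units; beyond the scatter).

No measurement here explains these steps. On these data alone, whether the methyl itself matters remains open, and an unsubstituted phenyl or a 4-aminophenyl at this position would help to show this.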